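A few compounds are considered here, and "the series" means these few. Any claim that something is new, unique, unknown or untested is made for them only; others in the source may bear on it.

Compound 2 `N#Cc1ccc(C(=O)Nc2ccc3nc(NC(=O)C4CCCCC4)sc3c2)cc1` gives 3.3 ug/mL in a functional assay on WI-38 VA13 cells (Homo sapiens) for cytotoxicity (on this read-out lower numbers stand for an effect already at smaller amounts and higher numbers for an effect only at larger amounts of compound), the highest of the three numbers recorded; compound 1 `O=C(Nc1ccc2nc(NC(=O)C3CCCCC3)sc2c1)c1cccc(F)c1` gives 0.64 ug/mL and compound 3 `O=C(Nc1ccc2nc(NC(=O)C3CCCCC3)sc2c1)c1c(Cl)cccc1Cl` gives 0.015 ug/mL. Compound 4 `Cc1cc(C(=O)Nc2ccc3nc(NC(=O)C4CCCCC4)sc3c2)c(C)n1C` differs from compound 2 in one place: 1,2,5-trimethyl-1H-pyrrol-3-yl in place of 4-cyanophenyl on a carbonyl carbon. Within the data shown here, no measured step swaps in a five-membered aromatic ring with one hetero atom, so the only bearing comes from the three aryl exchanges at the same carbonyl carbon, all of them beyond the scatter: a 5.2-fold higher number from compound 1 to compound 2 (0.71 log units; beyond the scatter), a 43-fold lower number from compound 1 to compound 3 (1.63 log units; beyond the scatter) and a 220-fold lower number from compound 2 to compound 3 (2.34 log units; beyond the scatter). Every change of the aryl group away from 4-cyanophenyl gave a lower number, and the exchanges span a wide range. Compound 4 is therefore expected to give a lower number than compound 2 in this assay, with the estimated step of a 6.6-fold lower number from compound 2 to compound 4 (0.82 log units; beyond the scatter). The estimate for compound 4 is 0.5 ug/mL, within a range from 0.05 ug/mL to 3.5 ug/mL.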

Compound 4, half-maximal effective concentration: > 6.2 ug/mL
Compound 4: no number, only a limit; the forecaster's own chance of this, stated with the estimate: 5%; middle value at least 12-fold (1.09 log units) away from the limit.
By their numbers in this assay, from the lowest: compound 3; then compound 1; then compound 2. At a limit, above all of these: compound 4.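

In this assay compound 4 gives no number, only a limit: the limit of > 6.2 ug/mL in this assay, at which 1 of the 4 values shown sits. Until now, every exchange away from 4-cyanophenyl on this carbonyl carbon had given a lower number, but 1,2,5-trimethyl-1H-pyrrol-3-yl does not continue that pattern, even though the floor of the step, an at least 1.8-fold higher number from compound 2 to compound 4 (0.27 log units; that floor lies within the scatter), does not separate the two compounds. The five-membered ring nevertheless stands clearly apart from the other two six-membered aromatic groups, with an at least 9.6-fold higher number from compound 1 to compound 4 (0.98 log units; beyond the scatter) and an at least 410-fold higher number from compound 3 to compound 4 (2.61 log units; beyond the scatter).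

Where compound 4 truly lies relative to compound 2 stays open, since only a limit is available. Also open, on these data alone, is whether the ring itself or its methyl groups matter here, a question that an unsubstituted pyrrol-3-yl or a thiophen-3-yl on this carbonyl carbon would address.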